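Working notes on two measured compounds and a third

This account rests on a few compounds, and the source may have more. Where it says the series, first, only, none or still open, it means among the compounds named here.

Measured so far:
compound 1 `Cc1cc2ccccc2nc1-c1cn(-c2ccc(F)cc2)nn1` — 65.6 ug/mL
compound 2 `CCCCCCCCCCn1cc(-c2nc3ccccc3cc2CC)nn1` — 12.7 ug/mL

In a functional assay on U-937 cells (Homo sapiens) for cytotoxicity, read by MTT assay, with a stated time of 24 h (on this read-out higher numbers stand for weaker inhibition and lower numbers for stronger inhibition), compound 1 gives 65.6 ug/mL and compound 2 gives 12.7 ug/mL. Among the measured compounds shown here, compound 2 stands at the lowest number of the two; its only neighbour is compound 1, whose higher number lies beyond the usual scatter, so compound 2 is the stronger inhibitor of the pair. The two differ in more than one place, so nothing is attributed to any single change between them.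

Compound 3 `CCCCCCCCCCn1cc(-c2nc3ccccc3cc2CCCCC)nn1` remains to be measured in this assay. Relative to compound 2 the difference is propyl in place of hydrogen on a saturated chain carbon, two bonds along the chain from an aromatic carbon. For the measured compounds named here, no comparable step is available among the measured compounds, so the step from compound 2 to compound 3 is expected to be small, likely within the scatter, with a slight lean toward a lower number, giving a 1.3-fold lower number from compound 2 to compound 3 (0.10 log units; within the scatter). Compound 3 is estimated at 10 ug/mL, with a range from 4 ug/mL to 30 ug/mL.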

Compound 3, half-maximal inhibitory concentration: 18.2 ug/mL
Compound 3: middle estimate off by 1.8-fold (0.26 log units), on the low side; the measured number falls inside the stated range.
By their numbers in this assay, from the lowest: compounds 2 and 3 (each within the scatter of the next); then compound 1.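

In this assay, among the compounds shown here, propyl in place of hydrogen on a saturated chain carbon, two bonds along the chain from an aromatic carbon, gives a 1.4-fold higher number from compound 2 to compound 3 (0.16 log units; within the scatter), the first comparison that differs in one place only. Ethyl and pentyl at this place therefore cannot be told apart on this read-out, so this chain carbon accepts the added propyl without a change beyond the scatter. Nothing at hand explains this result.

From the compounds shown here alone, a chain longer than pentyl at this place, or an amine or a carboxylic acid at its end, remains open. Going by these compounds, compound 1 differs from compound 2 and compound 3 in more than one place, so whether the same step would read alike with the group that compound 1 carries in place of the decyl chain also remains open.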